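Three thiazolidinones in a cell-growth assay

The compounds below may be only part of what the source reports. "The series", "measured", "known", "first", "only" and "open" are said of these compounds alone.

Compound 1 `COc1ccccc1N1C(=O)CSC1c1cc(F)cc(C(=O)O)c1`, compound 2 `COc1ccc(OC)c(N2C(=O)CSC2c2cccc(C(=O)NCCCCc3ccccc3)c2)c1`, compound 3 `COc1ccccc1N1C(=O)CSC1C(=O)NCCCCc1ccccc1`.

In a functional assay on HOS cells (Homo sapiens) for inhibition, read by CCK-8 assay, with a stated time of 72 h, tested at 1 uM (on this read-out higher numbers stand for more inhibition at the one concentration tested (going by the name of the read-out) and lower numbers for less inhibition), compound 1 gives 8%, compound 2 gives 5%, and compound 3 gives 0%. Compound 2 holds the second highest of the three numbers; its value sits within the scatter of compound 1 and also within the scatter of compound 3, so none of the three can be set apart from the others. Compound 4 `COc1c(F)cccc1N1C(=O)CSC1c1cccc(C(=O)NCCCCc2ccccc2)c1` has not yet been measured. It differs from compound 2 in one place: 3-fluoro-2-methoxyphenyl in place of 2,5-dimethoxyphenyl on an amide-type nitrogen in a ring. Going by the values given here, no pair of measured compounds differs in one place, so no step is known here. All three measured numbers lie close to one another and low, and the change to compound 4 is expected to bring no step beyond the scatter in this assay, as a number 1 percentage points higher from compound 2 to compound 4 (within the scatter). Compound 4 is therefore estimated at 6%, in a range from -5% to 18%.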

Compound 4, a percentage reported as inhibition, at one concentration (the size of the read-out at that concentration, not a potency): 9%
Compound 4: the middle estimate sits 3 percentage points below what was measured; the range from low to high includes it.
By their numbers in this assay, from the lowest: compounds 3, 2, 1 and 4 (each within the scatter of the next).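

Going by these compounds alone, the change from 2,5-dimethoxyphenyl to 3-fluoro-2-methoxyphenyl on the amide-type nitrogen in the ring gives, in this assay, a number 4 percentage points higher from compound 2 to compound 4 (within the scatter), the first step that can be read at this position. Replacing one methoxy group with a fluorine atom in this way therefore does not move the read-out beyond the scatter. Nothing at hand explains this result.

Going by these compounds, whether an amine or a carboxylic acid on this phenyl ring would bring a step beyond the scatter stays open. So does the effect of any group at this position other than these two.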